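A few compounds are considered here, and "the series" means these few. Any claim that something is new, unique, unknown or untested is made for them only; others in the source may bear on it.

Values measured in a functional assay on J774 cells (Mus musculus) for cytotoxicity; on this read-out lower numbers stand for stronger inhibition and higher numbers for weaker inhibition:
- compound 1 `CCCN(CCC)c1c([N+](=O)[O-])cc(S(=O)(=O)Nc2cccc(C)c2)cc1[N+](=O)[O-]`: 16000 nM
- compound 2 `CCCN(CCC)c1c([N+](=O)[O-])cc(S(=O)(=O)Nc2cccc(Cl)c2)cc1[N+](=O)[O-]`: 8700 nM

Only these two compounds have been measured so far, so compound 2 has a single neighbour to be compared with. Its value of 8700 nM lies within the usual scatter of the value for compound 1, and the two cannot be ranked. Compound 3 `CCCN(CCC)c1c([N+](=O)[O-])cc(S(=O)(=O)Nc2ccccn2)cc1[N+](=O)[O-]` keeps the shared core but carries pyridin-2-yl in place of 3-chlorophenyl on a sulfonamide nitrogen.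

Within the data shown here, the one measured step, chloro in place of methyl on an aromatic carbon, is a 1.8-fold lower number from compound 1 to compound 2 (0.26 log units; within the scatter). It bears on this change only loosely, since it alters a single substituent and leaves the aromatic ring itself untouched. Among the measured compounds shown here, no measured compound shows what a ring nitrogen does in this assay, so the evidence is thin and the range must stay wide. No shift beyond the scatter is expected, and the estimated step is a 1.6-fold higher number from compound 2 to compound 3 (0.21 log units; within the scatter). For compound 3 the expected value is 14000 nM, with an estimated range of 5000 nM to 40000 nM.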

Compound 3, half-maximal inhibitory concentration: 45000 nM
Estimate against measurement, compound 3: 3.2-fold (0.51 log units) below; the measured number lies above the stated range.
By their numbers in this assay, from the lowest: compounds 2 and 1 (each within the scatter of the next); then compound 3.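

Read in this assay the exchange of a carbon-only aromatic ring for pyridin-2-yl on the sulfonamide nitrogen gives a 5.2-fold higher number from compound 2 to compound 3 (0.71 log units; beyond the scatter) and also a 2.8-fold higher number from compound 1 to compound 3 (0.45 log units; beyond the scatter) so this position can move the number beyond the usual scatter, which the swap of chloro for methyl did not do. With both steps pointing the same way, compound 3 is the weakest inhibitor of the three in this cell assay, and the two compounds with a carbon-only ring cannot be ranked against each other. Nothing available explains why the ring with a nitrogen gives the higher number.

The change also does two things at once, since pyridin-2-yl brings a ring nitrogen and carries neither the chloro nor the methyl group, so these compounds cannot separate the two contributions. From the compounds shown here alone, a plain phenyl group would show what removing the substituent does alone, while pyridin-3-yl or pyridin-4-yl would show whether the place of the ring nitrogen matters, and an amine or a carboxylic acid on the ring remains unexplored.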